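A few compounds are considered here, and "the series" means these few. Any claim that something is new, unique, unknown or untested is made for them only; others in the source may bear on it.

In a functional assay on MV4-11 cells (Homo sapiens) for antiproliferative activity, read by CCK-8 assay, with a stated time of 72 h (on this read-out lower numbers stand for stronger inhibition and higher numbers for weaker inhibition), compound 1 (`Cn1cc(-c2ccccc2Oc2ccccc2)c2cc(C(=O)NCc3ccc(C(=O)Nc4ccccc4N)cc3)[nH]c2c1=O`) gives 80 nM. Compound 2 (`CC(C)Oc1ccccc1-c1cn(C)c(=O)c2[nH]c(C(=O)NCc3ccc(C(=O)Nc4ccccc4N)cc3)cc12`) gives 130 nM, and compound 3 (`Cn1cc(-c2ccccc2Oc2ccccc2)c2cc(C(=O)NCc3ccc(C(=O)NO)cc3)[nH]c2c1=O`) gives 570 nM. Compound 1 therefore sits with compound 2 at the stronger end of this small set, and only compound 3 stands clearly apart from it.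

Compound 4 (`Cn1cc(-c2cc(C(C)(C)O)ccc2Oc2ccccc2)c2cc(C(=O)NCc3ccc(C(=O)Nc4ccccc4N)cc3)[nH]c2c1=O`) has not yet been measured. It differs from compound 1 by one change: 1-hydroxy-1-methylethyl in place of hydrogen on an aromatic carbon. This is 1-hydroxy-1-methylethyl in place of hydrogen on an aromatic carbon, para to a phenoxy group and meta to a large group.

Two measured steps offer some guidance. Isopropyl in place of phenyl on the oxygen gives a 1.6-fold higher number from compound 1 to compound 2 (0.21 log units; within the scatter). This is the closer guide, as it alters the phenoxy group named in the new change, and it shows that a change there need not move the number much. Hydroxy in place of 2-aminophenyl gives a 7.1-fold higher number from compound 1 to compound 3 (0.85 log units; beyond the scatter), but that change lies elsewhere in the molecule and says little here. For the measured compounds named here, no measured compound carries the new group, so the direction remains uncertain.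

The expected result is a small upward move, a 1.3-fold higher number from compound 1 to compound 4 (0.10 log units; within the scatter), probably within the scatter. For compound 4 the estimated value is 100 nM, with an expected range from 35 nM to 300 nM.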

Compound 4, half-maximal inhibitory concentration: 100 nM
Beside the measured number, compound 4's estimate shows no gap at the digits printed; the measured number falls inside the stated range.
By their numbers in this assay, from the lowest: compounds 1, 4 and 2 (each within the scatter of the next); then compound 3.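

In this assay, putting 1-hydroxy-1-methylethyl on this aromatic carbon, para to a phenoxy group, where compound 1 carries only hydrogen, gives a 1.3-fold higher number from compound 1 to compound 4 (0.10 log units; within the scatter). The earlier steps shown here changed the group on the phenoxy oxygen and the group on the amide-type nitrogen, while this aromatic carbon kept its hydrogen in every measured compound, so they said nothing about substitution here. This step adds that information: a branched group of 4 heavy atoms, carrying a hydroxy group, can stand at this position in the compound 1 series and leave the number within the scatter in this cell assay.

On these data alone, a single substituent cannot show how much freedom this position allows, so it remains open whether a methyl group, an aminomethyl group or a carboxylic acid on the same carbon would also stay within the scatter, or whether any of them would move the number clearly in either direction. Why this large addition leaves the number within the scatter also remains unexplained, as no measurement shown here speaks to the cause of this result.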